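Working notes: the step from compound 2 to compound 3

The compounds below may be only part of what the source reports. "The series", "measured", "known", "first", "only" and "open" are said of these compounds alone.

- compound 1 `COc1ccc2nc(COc3ccc(CC4(O)SC(=O)NC4=O)cc3)n(C)c2c1` gives 7.33 ng.h/mL
- compound 2 `COc1ccc2nc(COc3ccc(CC(SC)C(N)=O)cc3)n(C)c2c1` gives 16.9 ng.h/mL

In an ADME assay on the whole organism (plasma) for pharmacokinetics, with Rhesus monkey (Macaca mulatta) as the target, read by LC-MS, at a dose of 1 mg/kg by the oral route (a higher number here means more compound in the circulation at the dose given, a lower number less compound in the circulation), compound 2 holds the higher of the two numbers. For the measured compounds named here, the only measured step is a 2.3-fold higher number from compound 1 to compound 2 (0.36 log units; beyond the scatter) and it is modest. Compound 3 `COc1ccc2nc(COc3ccc(CC(C(N)=O)[S+](C)[O-])cc3)n(C)c2c1` keeps the shared core and differs from compound 2 in one place. The change is a group of 3 heavy atoms (1 carbon, 1 oxygen, 1 sulfur; no ring) in place of a group of 2 heavy atoms (1 carbon, 1 sulfur; no ring), on a saturated chain carbon bound to a carbonyl carbon and a saturated chain carbon and it sits on a saturated chain carbon bound to a carbonyl carbon and a saturated chain carbon. Going by the values given here, no measured step covers this exchange. The step of a 2.3-fold higher number from compound 1 to compound 2 (0.36 log units; beyond the scatter) swapped a larger group, so it serves only as a loose guide to size. A modest move at most is therefore expected, slightly downward if anything, and the direction is uncertain. The expected step is a 1.4-fold lower number from compound 2 to compound 3 (0.15 log units; within the scatter) and this stays an estimate. For compound 3 the estimated value is 12 ng.h/mL within an expected range of 4 ng.h/mL to 40 ng.h/mL in this assay for now.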

Compound 3, area under the concentration-time curve: 36.7 ng.h/mL
For compound 3 the middle estimate is 3.1-fold (0.49 log units) below the measured one, within the range that was stated.
By their numbers in this assay, from the lowest: compound 1; then compound 2; then compound 3.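

In this assay, the group of 3 heavy atoms (1 carbon, 1 oxygen, 1 sulfur) in place of methylsulfanyl gives a 2.2-fold higher number from compound 2 to compound 3 (0.34 log units; beyond the scatter) and shows that this saturated chain carbon bound to a carbonyl carbon and a saturated chain carbon is sensitive to even a small exchange. Measured against the ring-bearing 5-hydroxy-2,4-dioxo-1,3-thiazolidin-5-yl group, the ring-free group of compound 3 gives a 5.0-fold higher number from compound 1 to compound 3 (0.70 log units; beyond the scatter) and so extends the gain seen with compound 2. No evidence at hand bears on this result.

The compounds shown leave open how an amine, a carboxylic acid or a longer chain in place of methylsulfanyl would read at this place. They also leave open whether the carbamoyl group has any part in these numbers.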